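The source may hold more compounds than are shown below. What is called first, only, known or untested is meant among the compounds shown, and "the series" means these compounds.

Compound 1 `COc1ccc(-c2cc(-c3ccc(S(N)(=O)=O)cc3)cnc2N)cn1` carries an unsubstituted sulfonamide on the shared core. In an in vitro ADME assay on microsomes from liver (Homo sapiens) for metabolic stability (on this read-out lower numbers stand for slow clearance and higher numbers for fast clearance), compound 1 gives only a limit of the assay, < 7 mL.min-1.g-1. Compound 2 `COc1ccc(-c2cc(-c3ccc(S(=O)(=O)NC4CC4)cc3)cnc2N)cn1` adds a cyclopropyl to the sulfonamide nitrogen, and in this assay compound 2 gives 15 mL.min-1.g-1. Compound 3 `COc1ccc(-c2cnc(N)c(-c3ccc(OC)nc3)c2)cn1`, which lacks the sulfonamide altogether, gives 19.9 mL.min-1.g-1 in this assay. Of the two numbers reported, compound 2 stands lowest, but compound 3 lies within the scatter of it, so the two cannot be ordered. For the measured compounds named here, the one measured step, an at least 2.1-fold higher number from compound 1 to compound 2 (0.33 log units; beyond the scatter), is only a lower bound on its size, since compound 1 sits at the limit of < 7 mL.min-1.g-1 in this assay, at which 1 of the 3 values shown sits.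

Compound 4 `COc1ccc(-c2cc(-c3ccc(-n4cncn4)cc3)cnc2N)cn1` differs from compound 2 by 1H-1,2,4-triazol-1-yl in place of cyclopropylsulfamoyl on an aromatic carbon. Going by the values given here, no measured step exchanges the sulfonamide for another group, so the measured step from compound 1 to compound 2 bears on it only loosely: it shows that this part of the molecule can shift the number beyond the scatter. The author expects a modest rise, a 1.7-fold higher number from compound 2 to compound 4 (0.22 log units; within the scatter), rather than a large one. Compound 4 is therefore estimated at 25 mL.min-1.g-1, within a range from 10 mL.min-1.g-1 to 60 mL.min-1.g-1 in this assay.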

Compound 4, intrinsic clearance in microsomes: 8 mL.min-1.g-1
Compound 4: middle estimate off by 3.1-fold (0.49 log units), on the high side, outside the stated range (below it).
By their numbers in this assay, from the lowest: compounds 4, 2 and 3 (each within the scatter of the next, the first and the last beyond it). At a limit, below all of these: compound 1.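

On an aromatic carbon of the six-membered aromatic ring of carbon only, para to a large group, the sulfonamide of compound 2 gives way to a 1H-1,2,4-triazol-1-yl ring with no hydrogen-bond donor and no sulfur, and in this assay this exchange yields a 1.9-fold lower number from compound 2 to compound 4 (0.27 log units; within the scatter) and so leaves compound 2 and compound 4 without an order, which shows that, for this pair, a number in this range does not depend on keeping a sulfonamide at this position. The comparison with the unsubstituted sulfonamide, an at least 1.1-fold higher number from compound 1 to compound 4 (0.05 log units; that floor lies within the scatter), gives only a floor, and that floor does not set the two compounds apart. Compound 1 gives a limit of the assay and not a number: the limit of < 7 mL.min-1.g-1 in this assay, at which 1 of the 4 values shown sits.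

The compounds shown leave open whether an imidazole, a primary amine or a carboxylic acid at this position would give a number beyond the scatter of compound 2 and compound 4. They also leave open whether a longer chain in place of cyclopropyl on the sulfonamide nitrogen would carry the number further from that of compound 2.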